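Naphthalenyl in Place of a Dimethyl Imide Ring

The source may report more compounds than this note shows. Statements on the series, on what has been measured and on what is new or still open speak of the compounds shown alone.

Compound 1, `O=C(OCC1=CCCN(CCCc2ccccc2)C1)c1ccccc1N1C(=O)CC(Cc2ccccc2)C1=O`, gives 3720 nM in an in vitro functional assay on HEK ts201 cells for antagonist activity at Neuronal acetylcholine receptor; alpha3/beta4 (Homo sapiens), read by fluorescence and calcium flux; a lower number here means a stronger inhibitor, a higher number a weaker inhibitor.
Compound 2, `CC1(C)CC(=O)N(c2ccccc2C(=O)OCC2CCCN(CCCc3ccccc3)C2)C1=O`, gives 5010 nM.
Compound 3, `O=C(OCC1CCCN(CCCn2cc(-c3ccccc3)nn2)C1)c1ccccc1-c1ccccc1`, gives 389000 nM.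

Among these three numbers compound 2 stands second highest; its nearest neighbour is compound 1, which lies within the scatter, while compound 3 lies far beyond the scatter with a much higher number. Compound 4, `O=C(OCC1CCCN(CCCc2ccccc2)C1)c1ccccc1-c1cccc2ccccc12`, has not been measured. It differs from compound 2 by naphthalen-1-yl in place of 3,3-dimethyl-2,5-dioxopyrrolidin-1-yl on an aromatic carbon. Within the data shown here, no measured pair isolates this change. Compound 3, which also has an aromatic ring where compounds 1 and 2 carry a five-membered non-aromatic ring with 1 hetero atom, shows a far higher number than compound 2, though its chain differs as well. A step to a higher number beyond the scatter is therefore expected, a 6.0-fold higher number from compound 2 to compound 4 (0.78 log units; beyond the scatter). Compound 4 is estimated to give 30000 nM, in a range from 5000 nM to 200000 nM.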

Compound 4, half-maximal inhibitory concentration: 63100 nM
For compound 4 the middle estimate is 2.1-fold (0.32 log units) below the measured one; measured number inside the range.
By their numbers in this assay, from the lowest: compounds 1 and 2 (each within the scatter of the next); then compound 4; then compound 3.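

On this aromatic carbon, naphthalen-1-yl in place of 3,3-dimethyl-2,5-dioxopyrrolidin-1-yl gives a 13-fold higher number from compound 2 to compound 4 (1.10 log units; beyond the scatter) and so a much weaker inhibitor. Among these compounds, this is the first comparison here that differs in one place only, so the loss belongs to this change alone, free of the chain difference carried by compound 3. Nothing shown here explains the loss.

As far as these compounds go, it remains open whether a carboxylic acid or a pyridinyl group on this carbon would keep the number close to that of compound 2.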